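Amide aryl swaps on the shared core: tolerability notes

The source may hold more compounds than are shown below. What is called first, only, known or untested is meant among the compounds shown, and "the series" means these compounds.

Compound 1 `COc1ccc(-c2cnc(NC(=O)c3ccn[nH]3)n2C)cc1`: in a toxicity assay on THP-1 cells (Homo sapiens) for inhibition (a higher number here means that more compound is tolerated, a lower number that less compound is tolerated), compound 1 reaches only the assay limit, > 100000 nM.
Compound 2 `COc1ccc(C(=O)Nc2ncc(-c3ccc(OC)cc3)n2C)cc1`: in this assay compound 2 likewise stops at the assay limit, > 100000 nM.
Compound 3 `COc1ccc(-c2cnc(NC(=O)c3cnc[nH]3)n2C)cc1`: in this assay compound 3 also gives only the assay limit, > 100000 nM.

Compound 3 stands at a limit rather than a number, and the two other values shown are limits as well, so no ranking among the three is possible. The change to compound 4 `COc1ccc(-c2cnc(NC(=O)c3ccccc3C#N)n2C)cc1` is 2-cyanophenyl in place of 1H-imidazol-5-yl on a carbonyl carbon. The measured steps that touch the same carbonyl carbon are a step that the two limits leave unreadable from compound 1 to compound 3 and a step that the two limits leave unreadable from compound 2 to compound 3; both are unreadable because of the limit of > 100000 nM in this assay, at which 3 of the 3 values shown sit. Every aryl or heteroaryl so far placed on this carbonyl has left the value at the limit, and readable numbers for any move off it are lacking. Compound 4 is therefore expected to sit at about 100000 nM, within 30000 nM to 300000 nM, most probably again reported as a limit. The step of a number no higher from compound 3 to compound 4 (the limit leaves the size open) is expected to be none beyond the scatter.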

Compound 4, half-maximal cytotoxic concentration: > 100000 nM
Compound 4 was reported as a limit (the forecaster's own chance of this, stated with the estimate: 70%); the middle value sits exactly at the limit.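

The steps from compound 1, compound 2 and compound 3 to compound 4 cannot be read, because all four compounds share one limit: the limit of > 100000 nM in this assay, at which 4 of the 4 values shown sit.

The compounds shown leave open whether changing the group on the carbonyl carbon alters the tolerated concentration in this assay at all.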